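One Added Methyl on a Benzyl Group

The source may hold more compounds than are shown below. What is called first, only, known or untested is meant among the compounds shown, and "the series" means these compounds.

Going by the values given here, in a functional assay on A2780 cells (Homo sapiens) for antiproliferative activity, read by resazurin assay, with a stated time of 72 h (a higher number here means a weaker inhibitor, a lower number a stronger inhibitor), compound 1 (`CN(Cc1ccccc1Br)C(=O)c1cc2c(Cc3ccccc3)n[nH]c2cc1O`) gives 1200 nM as the lower of the two numbers so far, and compound 2 (`CN(Cc1cccc(F)c1)C(=O)c1cc2c(Cc3ccccc3)n[nH]c2cc1O`) gives 5000 nM as the higher. Compound 3 (`Cc1cccc(Cc2n[nH]c3cc(O)c(C(=O)N(C)Cc4ccccc4Br)cc23)c1`) keeps the rest of compound 1 and differs by methyl in place of hydrogen on an aromatic carbon in one place, turning benzyl into 3-methylbenzyl. Among the compounds with values here, the only measured step is a 4.2-fold higher number from compound 1 to compound 2 (0.62 log units; beyond the scatter) and it puts 3-fluorophenyl in place of 2-bromophenyl while the benzyl stays untouched. That modest step shows how far one change moved the number in this pair, but it gives no direction for a new methyl. The expected step is therefore a 1.1-fold higher number from compound 1 to compound 3 (0.03 log units; within the scatter) and it stays within the scatter, though a modest move either way remains possible. Compound 3 is estimated at 1300 nM with 500 nM to 3200 nM as the likely range.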

Compound 3, half-maximal inhibitory concentration: 310 nM
Beside the measured number, compound 3's estimate is 4.2-fold (0.62 log units) above it; the whole stated range lies above it.
By their numbers in this assay, from the lowest: compound 3; then compound 1; then compound 2.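

The benzyl group stayed untouched in the earlier pair, and this result shows that it is not a silent part of the molecule: in this assay, methyl in place of hydrogen on its ring gives a 3.9-fold lower number from compound 1 to compound 3 (0.59 log units; beyond the scatter). A single added carbon here therefore moves the number about as far as replacing 2-bromophenyl with 3-fluorophenyl, which gives a 4.2-fold higher number from compound 1 to compound 2 (0.62 log units; beyond the scatter), but in the opposite direction. Nothing measured on these compounds bears on the reason for this shift.

Going by these compounds, whether the same effect would appear with the methyl on another carbon of the ring remains open, as does the outcome of placing an ethyl, a methoxy or an amine where the methyl sits. It is also unknown whether the 3-methylbenzyl group would lower the number when paired with the 3-fluorophenyl of compound 2.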